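Swapping Fluoro for Cyano on a Sulfonyl-Bearing Ring

The compounds below may be only part of what the source reports. "The series", "measured", "known", "first", "only" and "open" are said of these compounds alone.

Compound 3 `Cc1ccc2ncc(S(=O)(=O)c3cccc(F)c3)c(N3CCC(C)CC3)c2c1` gives 94% in an assay on isolated protein for displacement of a labelled ligand from metabotropic glutamate receptor 5 (Homo sapiens), with a stated time of 60 min, tested at 1 uM; on this read-out higher numbers stand for more inhibition at the one concentration tested (going by the name of the read-out) and lower numbers for less inhibition. Compound 1 `Cc1ccc2ncc(S(=O)(=O)c3cccc(C#N)c3)c(N3CCC(C)CC3)c2c1` differs from it only by cyano in place of fluoro on an aromatic carbon, and in this assay compound 1 gives 52%, a step of a number 42 percentage points lower from compound 3 to compound 1 (beyond the scatter). Compound 2 `COCC1CCN(c2c(S(=O)(=O)c3cccc(F)c3)cnc3cc(F)ccc23)CC1` gives 70.5% in this assay; how its core differs from the core of compound 3 is not broken down here. Compound 4 `COCC1CCN(c2c(S(=O)(=O)c3cccc(C#N)c3)cnc3cc(F)ccc23)CC1` has not yet been measured. It differs from compound 2 by cyano in place of fluoro on an aromatic carbon, the same change, at the same place, that turns compound 3 into compound 1. Because the earlier step was a number 42 percentage points lower from compound 3 to compound 1 (beyond the scatter), a step of a number 35.5 percentage points lower from compound 2 to compound 4 (beyond the scatter) is expected, though the lower start of compound 2 may hold the fall smaller. Compound 4 is therefore estimated at 35%, between 15% and 58%.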

Compound 4, a percentage reported as inhibition, at one concentration (the size of the read-out at that concentration, not a potency): 91%
The estimate for compound 4 lay 56 percentage points below the measured number, and the stated range ends below it.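

In this assay, the same swap of fluoro for cyano now gives a number 20.5 percentage points higher from compound 2 to compound 4 (beyond the scatter), which runs opposite to the earlier step. The change from 3-fluorophenyl to 3-cyanophenyl therefore does not carry over between these two cores, even in direction: the same change on two cores in this assay, a number 42 percentage points lower (beyond the scatter) from compound 3 to compound 1 and a number 20.5 percentage points higher (beyond the scatter) from compound 2 to compound 4, 62.5 percentage points apart, beyond the scatter of two such steps

For the compounds shown here, this shows that the outcome of the change depends on the core it sits on, but with only two pairs it does not show which difference between the cores matters, or why the direction reverses. The compounds shown leave open which part of the core decides the direction of the step. They also leave open how another group in the same place, such as a chlorine atom or an amine, would behave on each core.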